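A few compounds are considered here, and "the series" means these few. Any claim that something is new, unique, unknown or untested is made for them only; others in the source may bear on it.

Compounds measured so far:
- compound 1, `COc1ccc(NCN2C(=O)c3ccccc3C2=O)cc1`: 470 nM
- compound 2, `COc1ccc(NCN2C(=O)c3cccc(N)c3C2=O)cc1`: 3530 nM

In an assay on isolated protein for inhibition of ribosomal protein S6 kinase alpha-2 (Homo sapiens), read by fluorescence, with a stated time of 20 min (a lower number here means a stronger inhibitor, a higher number a weaker inhibitor), compound 1 gives 470 nM, the lowest of the two numbers available. Among the measured compounds shown here, the nearest neighbour is compound 2, which in this assay gives 3530 nM; the single measured step is a 7.5-fold higher number from compound 1 to compound 2 (0.88 log units; beyond the scatter), obtained with amino in place of hydrogen on an aromatic carbon of the shared core.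

The compound still to be measured is compound 3, `COc1ccc(NCN2C(=O)c3ccc(NC(=O)c4ccccc4)cc3C2=O)cc1`. Relative to compound 1 the change is benzamido in place of hydrogen on an aromatic carbon. For the measured compounds named here, the only step that bears on it is the one from compound 1 to compound 2, where a nitrogen-linked group on the core went with a weakening beyond the scatter; the benzamido group of compound 3 is a larger, amide-linked substituent, and it sits meta to a fused ring and para to a fused ring, so that step is an imperfect guide. On that basis compound 3 is expected to be somewhat weaker than compound 1, with the step estimated as a 2.8-fold higher number from compound 1 to compound 3 (0.44 log units; beyond the scatter). The estimate for compound 3 is 1300 nM, with a range from 350 nM to 5000 nM.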

Compound 3, half-maximal inhibitory concentration: 2160 nM
Compound 3: the middle estimate sits 1.7-fold (0.22 log units) below what was measured, and the stated range covers the measured number.
By their numbers in this assay, from the lowest: compound 1; then compounds 3 and 2 (each within the scatter of the next).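

In this assay, placing benzamido on this aromatic carbon, meta to a fused ring and para to a fused ring, gives a 4.6-fold higher number from compound 1 to compound 3 (0.66 log units; beyond the scatter). Read beside the earlier step, a 7.5-fold higher number from compound 1 to compound 2 (0.88 log units; beyond the scatter), this shows that the higher number is not confined to amino at one carbon: it also appears at a second aromatic carbon of the shared core, with a group of 9 heavy atoms that brings its own six-membered aromatic ring, and neither of these two substituted compounds goes against that pattern. Even so, the step remains modest for a group of this size, and no measured evidence is available to explain it.

The compounds shown leave open whether this step belongs to the amide link, to the added phenyl ring or to the position itself, a question that a plain amino group or an acetamido group on this same carbon would address. They also leave open whether a small group such as fluorine or methoxy on this carbon would stay level with compound 1 or give a lower number.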